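The source may report more compounds than this note shows. Statements on the series, on what has been measured and on what is new or still open speak of the compounds shown alone.

Measured compounds:
compound 1, `COc1cc(-c2cc(/C=C/C(=O)c3ccc(Cl)c(Cl)c3)[nH]n2)cc(OC)c1OC`: > 100000 nM
compound 2, `COc1ccc(-c2cc(/C=C/C(=O)c3ccc(N)cc3)[nH]n2)cc1OC`: > 100000 nM
compound 3, `COc1ccc(-c2cc(/C=C/C(=O)c3cc(OC)c(OC)c(OC)c3)[nH]n2)cc1OC`: > 100000 nM

Going by the values given here, the three compounds measured so far were tested in a functional assay on MOLT-4 cells (Homo sapiens) for inhibition, read by sulforhodamine B assay, with a stated time of 48 h; a higher number here means that more compound is tolerated, a lower number that less compound is tolerated. Compound 1 is reported only as a limit of the assay, > 100000 nM, and not as a number. Compound 2 likewise reaches only the limit > 100000 nM. Compound 3 also stands at the limit > 100000 nM. Compound 1 therefore stands nowhere in particular on the numbers shown: it sits at the same limit as both of its companions, a situation summed up by the limit of > 100000 nM in this assay, at which 3 of the 3 values shown sit.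

Compound 4, `COc1cc(-c2cc(/C=C/C(=O)c3ccc(F)c(F)c3)[nH]n2)cc(OC)c1OC`, has not yet been measured in this assay. It differs from compound 1 in one place: 3,4-difluorophenyl in place of 3,4-dichlorophenyl on a carbonyl carbon. Among the compounds with values here, no step between measured compounds exists to indicate what such an exchange does here, and since compound 1 offers only a limit, the size of any step from compound 1 to compound 4 cannot be read off. The expectation is that compound 4 will behave like compound 1, with no step beyond the usual scatter, so that the step of a number no higher from compound 1 to compound 4 (the limit leaves the size open) is expected to be nil and the assay is most likely to report a limit again. Compound 4 is thus estimated at 100000 nM, with a range from 30000 nM to 300000 nM.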

Compound 4, concentration lethal to 50% of the cells: > 100000 nM
Compound 4 ended at the assay's limit; the forecaster's own chance of this, stated with the estimate: 80%; the middle value sits exactly at the limit.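

In this assay compound 4 gives > 100000 nM as a limit of the assay and not a number. Going by these compounds alone, compound 1 likewise gives > 100000 nM as a limit, so no step between compound 1 and compound 4 can be read. The compounds shown leave open what value any of them would have beyond that limit: the limit of > 100000 nM in this assay, at which 4 of the 4 values shown sit.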